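A few compounds are considered here, and "the series" means these few. Any claim that something is new, unique, unknown or untested is made for them only; others in the source may bear on it.

Measured so far:
- compound 1 `O=C(OC1CCC(CN2CCN(c3cc(=O)c4cc(C(F)(F)F)cc([N+](=O)[O-])c4s3)CC2)CC1)c1ccc(F)cc1`: > 64 ug/mL
- compound 2 `CC(C)C(=O)OC1CCC(CN2CCN(c3cc(=O)c4cc(C(F)(F)F)cc([N+](=O)[O-])c4s3)CC2)CC1`: > 64 ug/mL

In an ADME assay on Vero cells (Chlorocebus sabaeus) for cytotoxicity, read by MTT assay, with a stated time of 48 h (on this read-out higher numbers stand for weaker inhibition and lower numbers for stronger inhibition), compound 1 gives only a limit, > 64 ug/mL. In this assay compound 2 likewise gives only a limit, > 64 ug/mL. Going by the values given here, the one comparable step is a step that the two limits leave unreadable from compound 1 to compound 2, and since (the limit of > 64 ug/mL in this assay, at which 2 of the 2 values shown sit), nothing can be read from it.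

Compound 3 `O=C(OC1CCC(CN2CCN(c3cc(=O)c4cc(C(F)(F)F)cc([N+](=O)[O-])c4s3)CC2)CC1)c1ccc2c(c1)OCC2` is the next ester in the row. Its change from compound 2 is a group of 9 heavy atoms (8 carbon, 1 oxygen; one five-membered non-aromatic ring with 1 hetero atom, one six-membered aromatic ring of carbon only) in place of a group of 3 heavy atoms (3 carbon; no ring), on a carbonyl carbon.

Among the compounds with values here, no measured step bears on this change in a readable way, so compound 3 is expected to stay at the limit, with the step of a number no higher from compound 2 to compound 3 (the limit leaves the size open) expected to be unreadable. The estimate for compound 3 in this assay is 64 ug/mL, within 32 ug/mL to 128 ug/mL.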

Compound 3, half-maximal inhibitory concentration: > 64 ug/mL
Compound 3 was reported as a limit; the forecaster's own chance of this, stated with the estimate: 80%; the middle value sits exactly at the limit.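

No step among compound 1, compound 2 and compound 3 can be read, since each value is only a limit: the limit of > 64 ug/mL in this assay, at which 3 of the 3 values shown sit.

The compounds shown leave open where each ester's true half-maximal inhibitory concentration lies, and whether the groups on the carbonyl carbon differ at all.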